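Enantiomer Pair in a Cytotoxicity Screen on HEp-2 Cells

This account rests on a few compounds, and the source may have more. Where it says the series, first, only, none or still open, it means among the compounds named here.

Three triazole-bearing compounds have been run in an ADME assay on HEp-2 cells (Homo sapiens) for cytotoxicity, read by MTT assay, with a stated time of 3 days; on this read-out lower numbers stand for higher toxicity in this test and higher numbers for lower toxicity in this test. Compound 1, `CCC[C@@H](CCn1cncn1)c1ccc(Cl)cc1`, gives 36.6 ug/mL in this assay. Compound 2, `c1ccc(C[C@@H](CCn2cncn2)c2ccccc2)cc1`, gives 55.9 ug/mL in this assay. Compound 3, `Clc1ccc([C@@H](CCn2cncn2)Cc2ccccc2)cc1`, gives 25.9 ug/mL in this assay. Compound 3 and compound 1 lie within the scatter of each other, so nothing separates them, while compound 2 sits beyond the scatter above compound 3, the only clear gap among the three.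

Compound 4, `Clc1ccc([C@H](CCn2cncn2)Cc2ccccc2)cc1`, is the mirror partner of compound 3: the two compounds have the same atoms and bonds and differ only in configuration as drawn: 1 of 1 stereo elements differ; a stereocentre at a saturated chain carbon is drawn R in compound 3 and S in compound 4. Among the compounds with values here, no pair among the measured compounds shows what such a change does to this read-out, and no other difference between the two exists that could be drawn upon. Cytotoxicity read-outs of this sort frequently treat both configurations alike, so no step beyond the scatter in this assay is expected in either direction. The estimate for compound 4 in this assay is therefore 30 ug/mL, with a range from 15 ug/mL to 60 ug/mL, which means an expected step of a 1.2-fold higher number from compound 3 to compound 4 (0.06 log units; within the scatter) that stays within the scatter. The measurement will show whether the configuration matters here.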

Compound 4, half-maximal cytotoxic concentration: 25.7 ug/mL
The estimate for compound 4 lay 1.2-fold (0.07 log units) above the measured number; the range from low to high includes it.
By their numbers in this assay, from the lowest: compounds 4, 3, 1 and 2 (each within the scatter of the next, the first and the last beyond it).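

Within the data shown here, for the first time, a pair in this assay isolates the stereocentre at a saturated chain carbon. The reading is a 1.0-fold lower number from compound 3 to compound 4 (0.00 log units; within the scatter), so drawing this centre R or S does not separate the pair, and no other structural difference enters this comparison: the fact that compounds 3 and 4 differ only in the configuration as drawn

Among these compounds, the new data also give the first single-place comparisons for two other changes, with chloro in place of hydrogen on an aromatic carbon giving a 2.2-fold lower number from compound 2 to compound 4 (0.34 log units; beyond the scatter), a modest step beyond the scatter, while phenyl in place of ethyl on a saturated chain carbon, two bonds along the chain from an aromatic carbon, gives a 1.4-fold lower number from compound 1 to compound 4 (0.15 log units; within the scatter), which remains within the scatter and so cannot be resolved in this read-out.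

From the compounds shown here alone, whether the configuration is equally silent with an ethyl group or with hydrogen in place of chloro on the aromatic carbon remains open. Going by these compounds, it is also open what bromo or methoxy in place of chloro, or an amine or a longer chain in place of the phenyl, would do in this assay.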